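From 3,4-dimethoxyphenyl to phenyl: a growth inhibition estimate

The source may report more compounds than this note shows. Statements on the series, on what has been measured and on what is new or still open speak of the compounds shown alone.

Measured so far:
compound 1 `COc1cccc(/C=C/C(=O)/C=C/c2ccc(OCc3cn(CCCOc4cc(=O)oc5ccccc45)nn3)c(OC)c2)c1`: 52%
compound 2 `COc1ccc(/C=C/C(=O)/C=C/c2ccc(OCc3cn(CCCOc4cc(=O)oc5ccccc45)nn3)c(OC)c2)cc1OC`: 65%

In a functional assay on COLO 205 cells (Homo sapiens) for inhibition, read by sulforhodamine B assay, with a stated time of 48 h, tested at 50 uM (a lower number here means less inhibition of growth, a higher number more inhibition of growth at the concentration tested), compound 2 gives 65% as the higher of the two numbers. Compound 3 `COc1cc(/C=C/C(=O)/C=C/c2ccccc2)ccc1OCc1cn(CCCOc2cc(=O)oc3ccccc23)nn1` has not been measured yet. It differs from compound 2 in one place: phenyl in place of 3,4-dimethoxyphenyl on a double-bonded chain carbon bound to a double-bonded chain carbon.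

Going by the values given here, only one measured step bears on this. Among the compounds with values here, a methoxy in place of hydrogen on an aromatic carbon went with a number 13 percentage points higher from compound 1 to compound 2 (beyond the scatter) in this assay as the sole evidence. Compound 3 has no methoxy on that ring, so the change runs the opposite way and a lower number is expected. One step is thin support, so the size remains uncertain. The expected change is a number 15 percentage points lower from compound 2 to compound 3 (beyond the scatter) on this reading. For compound 3 the estimate is 50% (expected range 34% to 65%).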

Compound 3, percent growth inhibition at one concentration: 43%
Compound 3: the middle estimate sits 7 percentage points above what was measured; the measured number falls inside the stated range.
By their numbers in this assay, from the lowest: compounds 3 and 1 (each within the scatter of the next); then compound 2.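

In this assay, replacing the 3,4-dimethoxyphenyl with plain phenyl gives a number 22 percentage points lower from compound 2 to compound 3 (beyond the scatter) and shows that growth inhibition at this position depends on what the ring carries. The other new step, a number 9 percentage points lower from compound 1 to compound 3 (within the scatter) on removing the methoxy of compound 1, cannot be read as a real change, so the clear loss appears only when the starting point is the 3,4-dimethoxyphenyl compound. Nothing available explains this difference.

The compounds shown leave open whether a hydroxyl, an amine or a fluorine on this ring would match the 3,4-dimethoxyphenyl or fall with the phenyl. They also leave open whether these differences would hold at concentrations other than the single one tested.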